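Replacing naphthalen-1-yl with 3-chlorophenyl on the shared core

The compounds below may be only part of what the source reports. "The series", "measured", "known", "first", "only" and "open" are said of these compounds alone.

Measured in a functional assay on MDA-MB-231 cells (Homo sapiens) for antiproliferative activity, with a stated time of 5 days; a higher number here means a weaker inhibitor, a lower number a stronger inhibitor:
- compound 1 `O=C1C=CC2(C=C1)OCC(=O)N2c1nc(-c2ccc3ccccc3c2Br)nn1-c1ccccc1`: 50 nM
- compound 2 `O=C1C=CC2(C=C1)OCC(=O)N2c1nc(-c2cccc3ccccc23)nn1-c1ccccc1`: 50 nM

Compound 2, at 50 nM, stands level with compound 1. The next entry is compound 3 `O=C1C=CC2(C=C1)OCC(=O)N2c1nc(-c2cccc(Cl)c2)nn1-c1ccccc1`, with 3-chlorophenyl in place of naphthalen-1-yl on an aromatic carbon. Among the measured compounds shown here, the only measured step at this place is no change at the digits printed from compound 1 to compound 2 (within the scatter), and it lies within the scatter. That step kept two six-membered aromatic rings of carbon only, whereas the new group has one, so no measurement covers this change directly. On the evidence of no change at the digits printed from compound 1 to compound 2 (within the scatter), no clear change is expected in this assay, with a slight lean towards a weaker value. The expected size is a 1.2-fold higher number from compound 2 to compound 3 (0.08 log units; within the scatter). For compound 3 the estimated value is 60 nM, with an expected range of 25 nM to 150 nM.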

Compound 3, half-maximal inhibitory concentration: 0.8 nM
For compound 3 the middle estimate is 75-fold (1.88 log units) above the measured one; measured number below the stated range.
By their numbers in this assay, from the lowest: compound 3; then compounds 1 and 2 (each within the scatter of the next).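

In this assay the aromatic carbon of the five-membered ring turns out to be sensitive to its aryl group, which the step between the two naphthalene-bearing compounds did not reveal: 3-chlorophenyl gives (a 63-fold lower number from compound 2 to compound 3 (1.80 log units; beyond the scatter)) against naphthalen-1-yl and (a 63-fold lower number from compound 1 to compound 3 (1.80 log units; beyond the scatter)) against 1-bromonaphthalen-2-yl. Each step goes from two six-membered aromatic rings of carbon only to one and also brings in a chlorine on that ring, so the two changes stand together and these compounds cannot separate them. No measurement here accounts for the size of these steps.

Open, on these data alone, is how much of the gain depends on the chlorine, a question that plain phenyl, 3-methylphenyl or 3-methoxyphenyl at this place would address. Also open, as far as these compounds go, is whether the chlorine must sit as in 3-chlorophenyl, or whether 4-chlorophenyl or 2-chlorophenyl would read the same.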